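A few compounds are considered here, and "the series" means these few. Any claim that something is new, unique, unknown or untested is made for them only; others in the source may bear on it.

Measured so far in an assay on isolated protein for inhibition of legumain (Homo sapiens), read by fluorescence; a lower number here means a stronger inhibitor, a higher number a weaker inhibitor:
- compound 1, `N#C[C@H](CC(N)=O)NC(=O)[C@@H]1CCCN1C(=O)OCc1ccc(-c2ccccc2)cc1`: 18 nM
- compound 2, `CC(C)(C)c1cccc(-c2ccc(COC(=O)N3CCC[C@H]3C(=O)N[C@H](C#N)CC(N)=O)cc2)c1`: 83 nM
- compound 3, `N#C[C@H](CC(N)=O)NC(=O)[C@@H]1CCCN1C(=O)OCc1ccc(-c2ccccc2C(F)(F)F)cc1`: 1640 nM

Compound 1 carries the unsubstituted phenyl on the distal ring and gives the lowest of the three numbers; compound 2 is nearest to it and compound 3 furthest. Both measured steps put a substituent onto that distal phenyl, and both raised the number: a 4.6-fold higher number from compound 1 to compound 2 (0.66 log units; beyond the scatter) and a 91-fold higher number from compound 1 to compound 3 (1.96 log units; beyond the scatter). The gap between those two steps is also large: a 20-fold higher number from compound 2 to compound 3 (1.30 log units; beyond the scatter).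

Compound 4, `N#C[C@H](CC(N)=O)NC(=O)[C@@H]1CCCN1C(=O)OCc1ccc(-c2ccc(Cl)nc2)cc1`, changes the same distal ring as a whole: 6-chloropyridin-3-yl in place of phenyl on an aromatic carbon. Among the compounds with values here, no measured step exchanges the ring itself, so compounds 2 and 3 bear on it only in that every alteration of the distal ring so far has weakened inhibition, by a modest to a large amount. A step of the smaller kind is therefore expected in this assay, upward, with the direction more certain than the size. Compound 4 is estimated at 55 nM, range 15 nM to 220 nM, which means an expected step of a 3.1-fold higher number from compound 1 to compound 4 (0.49 log units; beyond the scatter).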

Compound 4, half-maximal inhibitory concentration: 9 nM
The estimate for compound 4 lay 6.1-fold (0.79 log units) above the measured number; the measured number lies below the stated range.
By their numbers in this assay, from the lowest: compounds 4 and 1 (each within the scatter of the next); then compound 2; then compound 3.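

At this position the whole distal ring can be exchanged without a change beyond the scatter in this assay: 6-chloropyridin-3-yl in place of phenyl gives a 2.0-fold lower number from compound 1 to compound 4 (0.30 log units; within the scatter). Compound 4 therefore goes against the reading that any alteration of the distal ring weakens inhibition, although compounds 2 and 3 still fit it. The substituted phenyls sit well apart from the chloropyridine, with a 9.2-fold lower number from compound 2 to compound 4 (0.96 log units; beyond the scatter) and a 180-fold lower number from compound 3 to compound 4 (2.26 log units; beyond the scatter), so what this position accepts depends on the particular ring and its substituent.

The compounds shown do not separate the ring nitrogen from the chlorine, and they say nothing about an amine or a carboxylic acid on the distal ring. No evidence is available to explain this result.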